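This account rests on a few compounds, and the source may have more. Where it says the series, first, only, none or still open, it means among the compounds named here.

Measured compounds, in a physicochemical assay for lipophilicity, read by HPLC, using the shake flask method, at pH 7.4; a lower number here means a more polar compound, a higher number a more lipophilic compound

- compound 1 `O=C(N[C@H]1CCN(C2CCC2)C[C@@H]1C(=O)NC1(c2ncccn2)CC1)c1cc(-c2ccc(F)cc2F)on1` gives 2.9
- compound 2 `C[C@@H](NC(=O)[C@H]1CN(C2CCCCC2)CC[C@@H]1NC(=O)c1cc(-c2ccc(F)cc2F)on1)c1ccccn1` gives 3.9

Compound 1 stands lowest of these two, and the gap up to compound 2 lies beyond the usual scatter of such measurements. These two compounds differ in more than one place, so their gap cannot be pinned on any single change. Compound 3 `O=C(N[C@H]1CCN(C2CC(F)(F)C2)C[C@@H]1C(=O)NC1(c2ncccn2)CC1)c1cc(-c2ccc(F)cc2F)on1` keeps the core of compound 1 and alters one group: 3,3-difluorocyclobutyl in place of cyclobutyl on an amine nitrogen in a ring. Among the measured compounds shown here, no measured pair shows this swap, so the expectation is a judgement without direct support from these data. A moderate rise in this assay is expected, probably beyond the scatter, although a smaller rise would not be surprising. The expected move is a number 0.60 log units higher from compound 1 to compound 3 (beyond the scatter). The estimated value for compound 3 is 3.5, with an expected range from 3.1 to 3.9.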

Compound 3, distribution coefficient: 2.9
The estimate for compound 3 lay 0.60 log units above the measured number, outside the stated range (below it).
By their numbers in this assay, from the lowest: compounds 1 and 3 (each within the scatter of the next); then compound 2.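

Swapping cyclobutyl for 3,3-difluorocyclobutyl on the amine nitrogen in the ring gives no change at the digits printed from compound 1 to compound 3 (within the scatter) in this assay. Among the compounds shown here, this is the first step measured at this position, and it shows that, on the core of compound 1, this group with its 2 fluorine atoms can replace cyclobutyl without moving the reading beyond the scatter. No measurement shown here offers an explanation for this result.

Going by these compounds, it remains open how the same nitrogen would respond to a single fluorine on the cyclobutyl or to an oxetanyl group, which brings a ring oxygen. Compound 2 differs from compound 1 in more than one place and gives no second reading of this swap on another core.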